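This account rests on a few compounds, and the source may have more. Where it says the series, first, only, none or still open, it means among the compounds named here.

Measured compounds in a functional assay on HPAC cells (Homo sapiens) for inhibition, read by MTT assay, with a stated time of 72 h; on this read-out lower numbers stand for stronger inhibition of growth and higher numbers for weaker inhibition of growth:

Compound 1 `CC(C)(C)c1ccc(CNCCCNS(=O)(=O)c2cc(C(F)(F)F)cc(C(F)(F)F)c2)cc1` gives 2300 nM.
Compound 2 `O=S(=O)(NCCCNCc1ccc(Cl)c(Cl)c1)c1cc(C(F)(F)F)cc(C(F)(F)F)c1` gives 2500 nM.
Compound 3 `O=S(=O)(NCCCNCc1ccc(Cl)c(C(F)(F)F)c1)c1cc(C(F)(F)F)cc(C(F)(F)F)c1` gives 3000 nM.

Compound 3 holds the highest of the three numbers, but its neighbours lie close: the step of a 1.2-fold higher number from compound 2 to compound 3 (0.08 log units; within the scatter) and the step of a 1.3-fold higher number from compound 1 to compound 3 (0.12 log units; within the scatter) both fall within the scatter, so the three compounds cannot be separated on these numbers. Compound 4 `O=S(=O)(NCCCNCc1ccc(C(F)(F)F)cc1)c1cc(C(F)(F)F)cc(C(F)(F)F)c1` arises from compound 3 by one change, (4-(trifluoromethyl)phenyl in place of 4-chloro-3-(trifluoromethyl)phenyl on a saturated chain carbon bound to an amine nitrogen). Within the data shown here, three measured steps bear on this kind of change. Two of them swap the whole aryl group at the same place, a 1.1-fold higher number from compound 1 to compound 2 (0.04 log units; within the scatter) and a 1.3-fold higher number from compound 1 to compound 3 (0.12 log units; within the scatter), and one swaps a single substituent on that aryl, a 1.2-fold higher number from compound 2 to compound 3 (0.08 log units; within the scatter); none moves beyond the scatter. The removal of the chloro in going to compound 4 is therefore expected to give no step beyond the scatter, and the estimated step is no change at the digits printed from compound 3 to compound 4 (within the scatter). On that basis compound 4 is expected to give about 3000 nM in this assay, with a plausible range from 1500 nM to 6500 nM.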

Compound 4, concentration for 50% growth inhibition: 2700 nM
The estimate for compound 4 lay 1.1-fold (0.05 log units) above the measured number; the measured number falls inside the stated range.
By their numbers in this assay, from the lowest: compounds 1, 2, 4 and 3 (each within the scatter of the next).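

In this assay, among these compounds, compound 4 gives the first step at this position that takes a substituent away rather than exchanging one aryl group for another, and removing the chloro stays small, with a 1.1-fold lower number from compound 3 to compound 4 (0.05 log units; within the scatter). The comparisons with the other two compounds, a 1.1-fold higher number from compound 2 to compound 4 (0.03 log units; within the scatter) and a 1.2-fold higher number from compound 1 to compound 4 (0.07 log units; within the scatter), are also within the scatter, so the 4-(trifluoromethyl)phenyl group cannot be separated from any of the other three aryl groups on the saturated chain carbon bound to an amine nitrogen. No measurement is at hand that could explain this result. The compounds shown leave open whether an unsubstituted phenyl, a pyridine or a cyclohexyl group at this place would give a step beyond the scatter. They also leave open what a carboxylic acid on the aryl group or a longer chain in the shared core would do.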